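The compounds below may be only part of what the source reports. "The series", "measured", "known", "first", "only" and "open" are said of these compounds alone.

Among the measured compounds shown here, in a functional assay on HeLa cells (Homo sapiens) for antiproliferative activity, read by CCK-8 assay, with a stated time of 72 h (a lower number here means a stronger inhibitor of growth, a higher number a weaker inhibitor of growth), only two related compounds have been examined so far. For the measured compounds named here, compound 1 (`CCCCNS(=O)(=O)c1ccc(Nc2ncc3c(n2)N(C2CCCC2)[C@H](CC)C(=O)N3C)cc1`) gives 451 nM in this assay and is the only one with a number. Compound 2 (`CCC1C(=O)N(C)c2cnc(-n3ccc4cc(F)ccc43)nc2N1c1ccn(C)n1`) is recorded as "not active" (no number reported) in the same test, so it has no numerical position and can only be described as lacking a reported value. Compound 3 (`CCNC(=O)c1ccc2c(ccn2-c2ncc3c(n2)N(c2ccn(C)n2)C(CC)C(=O)N3C)c1`) has not yet been measured. The structural change is ethylcarbamoyl in place of fluoro on an aromatic carbon and it falls on an aromatic carbon of a six-membered aromatic ring of carbon only, where ethylcarbamoyl stands in place of fluoro. Going by the values given here, no measured pair shows what this exchange does, so the expectation is tentative. A modest step toward stronger growth inhibition is expected, from no reported number to a measurable but weak value, with a real chance that no number appears again. Even then, the result would probably remain weaker than compound 1 at 451 nM in this assay. Compound 3 is estimated at 2000 nM with an expected range from 350 nM to 10000 nM for this measurement.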

Compound 3, concentration for 50% growth inhibition: 11100 nM
Compound 3: middle estimate off by 5.6-fold (0.74 log units), on the low side, outside the stated range (above it).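

Among the compounds shown here, compound 2 has no number in this assay, and no step from it to compound 3 can be read. The compounds shown leave open what ethylcarbamoyl in place of fluoro does to growth inhibition in this assay. No independent evidence is available that bears on the result for compound 3.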